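Cinnamamide analogues of a trimethoxybenzophenone core tested for cytotoxicity

A few compounds are considered here, and "the series" means these few. Any claim that something is new, unique, unknown or untested is made for them only; others in the source may bear on it.

Compounds measured so far:
compound 1, `COc1cc(C(=O)c2cc(OC)c(OC)c(OC)c2)cc(NC(=O)/C=C/c2cc(OC)c(OC)c(OC)c2)c1OC`, 2500 nM
compound 2, `COc1ccc(/C=C/C(=O)Nc2cc(C(=O)c3cc(OC)c(OC)c(OC)c3)cc(OC)c2OC)cc1OC`, 2700 nM
compound 3, `COc1cccc(/C=C/C(=O)Nc2cc(C(=O)c3cc(OC)c(OC)c(OC)c3)cc(OC)c2OC)c1`, 6900 nM

All three share a core that carries a cinnamamide arm, and they were tested in a functional assay on HeLa cells (Homo sapiens) for cytotoxicity, read by MTT assay, with a stated time of 72 h; on this read-out higher numbers stand for weaker inhibition and lower numbers for stronger inhibition. Compound 3 stands at the weak end of the three numbers: its nearest neighbour is compound 2, and the gap between them is a 2.6-fold higher number from compound 2 to compound 3 (0.41 log units; beyond the scatter), while the other gap is a 2.8-fold higher number from compound 1 to compound 3 (0.44 log units; beyond the scatter). Compound 1 and compound 2 lie within the scatter of each other, as shown by a 1.1-fold higher number from compound 1 to compound 2 (0.03 log units; within the scatter).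

Compound 4, `COc1ccc(/C=C/C(=O)Nc2cc(C(=O)c3cc(OC)c(OC)c(OC)c3)cc(OC)c2OC)cc1N`, has not yet been measured. It differs from compound 3 by 3-amino-4-methoxyphenyl in place of 3-methoxyphenyl on a double-bonded chain carbon bound to a double-bonded chain carbon. Among the compounds with values here, the step from compound 3 to compound 2 is the only measured step that comes close to this change, since it also restores a group on the same position of the ring, and it was a modest gain. Nothing measured speaks to an amino group on this ring. The account therefore expects compound 4 to fall near compound 2, an estimated step of a 2.8-fold lower number from compound 3 to compound 4 (0.44 log units; beyond the scatter) in this assay. Compound 4 is expected to give about 2500 nM, within a range from 900 nM to 7000 nM.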

Compound 4, half-maximal inhibitory concentration: 15800 nM
Estimate against measurement, compound 4: 6.3-fold (0.80 log units) below; the measured number lies above the stated range.
By their numbers in this assay, from the lowest: compounds 1 and 2 (each within the scatter of the next); then compound 3; then compound 4.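

In this assay, within the data shown here, the earlier compounds carried only methoxy groups on this ring, and compound 4 shows that an amino group cannot stand in for one: amino in place of methoxy gives a 5.9-fold higher number from compound 2 to compound 4 (0.77 log units; beyond the scatter). The 3-methoxyphenyl group of compound 3 had already given a weaker number than the more heavily substituted rings, yet 3-amino-4-methoxyphenyl in its place gives a 2.3-fold higher number from compound 3 to compound 4 (0.36 log units; beyond the scatter), so a further group on this ring does not by itself bring the number back, and the identity of that group matters. Against the 3,4,5-trimethoxyphenyl arm the change amounts to a 6.3-fold higher number from compound 1 to compound 4 (0.80 log units; beyond the scatter), and nothing available explains this loss.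

The compounds shown leave open whether the loss follows the free amino group alone or would persist with a hydroxyl, a dimethylamino or an acetamide at the same place on the ring. They also leave open how a 3-aminophenyl group, carrying the amine without the methoxy, would compare with compound 3 and compound 4.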